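Swapping an ethylphenyl for a fluorophenyl on sulfur

A few compounds are considered here, and "the series" means these few. Any claim that something is new, unique, unknown or untested is made for them only; others in the source may bear on it.

Compound 1 `Nc1ccccc1NC(=O)/C=C/c1ccc(CSc2cccc(F)c2)cc1`: 2.25%
Compound 2 `CCc1ccc(SCc2ccc(/C=C/C(=O)Nc3ccccc3N)cc2)cc1`: 3.96%
Compound 3 `CCc1ccc(SCc2ccc(C(=O)Nc3ccccc3N)cc2)cc1`: 30.8%

In a functional assay on HeLa cells (Homo sapiens) for inhibition, read by CCK-8 assay, with a stated time of 72 h, tested at 2 uM (on this read-out higher numbers stand for more inhibition of growth at the one concentration tested and lower numbers for less inhibition of growth), compound 3 gives 30.8%, the highest of the three values. The difference between the core of compound 3 and the core of compound 2 is not broken down here. Compound 2 and compound 1 share a core and differ only in the group on the sulfur: 3-fluorophenyl in place of 4-ethylphenyl on a sulfur. That change made a step of a number 1.7 percentage points lower from compound 2 to compound 1 (within the scatter).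

Compound 4 `Nc1ccccc1NC(=O)c1ccc(CSc2cccc(F)c2)cc1` has not yet been measured in this assay. It differs from compound 3 by the same change at the same place: 3-fluorophenyl in place of 4-ethylphenyl on a sulfur. Since the earlier step of a number 1.7 percentage points lower from compound 2 to compound 1 (within the scatter) was within the scatter, a similarly small step is expected here. The expected step is a number 1.8 percentage points lower from compound 3 to compound 4 (within the scatter). Compound 4 is therefore estimated to give about 29%, likely between 15% and 42%.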

Compound 4, percent growth inhibition at one concentration: 22.5%
For compound 4 the middle estimate is 6.5 percentage points above the measured one; low and high end bracket the measured number.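

In this assay, putting 3-fluorophenyl in place of 4-ethylphenyl on the sulfur gave a number 8.3 percentage points lower from compound 3 to compound 4 (within the scatter). The swap therefore behaves alike on both cores, with no real gap between its two steps: the same change on two cores in this assay, a number 1.7 percentage points lower (within the scatter) from compound 2 to compound 1 and a number 8.3 percentage points lower (within the scatter) from compound 3 to compound 4, 6.6 percentage points apart, within the scatter of two such steps. For the compounds shown here, this agreement rests on only two pairs, and since both steps lie within the scatter, it does not show that the swap has a real effect on either core or that it would stay this small on a third core.

The compounds shown leave open how the series would respond to a quite different group on the sulfur, such as a longer saturated chain or a phenyl ring carrying an amine or a carboxylic acid.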